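The source may report more compounds than this note shows. Statements on the series, on what has been measured and on what is new or still open speak of the compounds shown alone.

Values measured so far in a functional assay on MCF7 cells (Homo sapiens) for cytotoxicity, read by MTT assay, with a stated time of 72 h (a higher number here means a weaker inhibitor, a lower number a stronger inhibitor), are as follows.

Compound 1 `O=C1c2c[n+]([O-])c3ccccc3c2C(=O)c2c1c1ccccc1n2CCCCn1ccnc1` gives 130 nM
Compound 2 `CC1(C)OCC(Cn2cc(Cn3c4c(c5ccccc53)C(=O)c3c[n+]([O-])c5ccccc5c3C4=O)nn2)O1` gives 290 nM
Compound 3 `CCCCN1CCN(CCCCn2c3c(c4ccccc42)C(=O)c2c[n+]([O-])c4ccccc4c2C3=O)CC1` gives 6900 nM

Of these three numbers, compound 2 holds the second highest, with 290 nM lying between the values of the other two compounds. The next compound to be tested is compound 4 `CC1(C)OC[C@@H](Cn2cc(Cn3c4c(c5ccccc53)C(=O)c3c[n+]([O-])c5ccccc5c3C4=O)nn2)O1`. Its relation to compound 2 is the two compounds have the same atoms and bonds; at least one stereo element is drawn with a configuration in one of them and without one in the other: 1 of 1 stereo elements differ; a stereocentre at a saturated ring carbon is drawn without a configuration in compound 2 and R in compound 4 and the two have the same atoms and bonds. A stereocentre at a saturated ring carbon is drawn without a configuration in compound 2 and R in compound 4.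

Among the compounds with values here, only one single-site step has been measured, and it is large: a 53-fold higher number from compound 1 to compound 3 (1.72 log units; beyond the scatter). That step places 4-butylpiperazin-1-yl in place of 1H-imidazol-1-yl, so it concerns a different kind of change and offers no size for this one. Within the data shown here, no measured pair tests a configuration. With no evidence for a shift in either direction, no step beyond the scatter is expected in this assay here. The expected change is a 1.0-fold lower number from compound 2 to compound 4 (0.02 log units; within the scatter) as estimated. The estimated value for compound 4 is 280 nM, with an expected range from 130 nM to 600 nM as its limits.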

Compound 4, half-maximal inhibitory concentration: > 1000 nM
Compound 4: a limit, no number (the forecaster's own chance of this, stated with the estimate: 2%); at least 3.5-fold (0.55 log units) between middle value and limit.
By their numbers in this assay, from the lowest: compound 1; then compound 2; then compound 3.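

In this assay, within the data shown here, the compounds give a first measure of a change that leaves the atoms and bonds untouched: an at least 3.4-fold higher number from compound 2 to compound 4 (0.53 log units; beyond the scatter). For compound 4 the reading of > 1000 nM is a limit and not a number: the limit of > 1000 nM in this assay, at which 1 of the 4 values shown sits. The earlier step, a 53-fold higher number from compound 1 to compound 3 (1.72 log units; beyond the scatter), exchanged one group for another, whereas this pair shows that the number in this assay can also move beyond the scatter with a single stereocentre at a saturated ring carbon as the only difference, drawn without a configuration in compound 2 and R in compound 4: the fact that one of compounds 2 and 4 is drawn with a defined configuration and the other without, at the place where they differ.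

The compounds shown leave open how the S configuration at this carbon would read and how far the true value of compound 4 lies past its limit. They also do not tell whether the same sensitivity would persist if the ring carrying this stereocentre gave way to an open-chain diol or a carboxylic acid.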